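Trimming a tert-butyl group to isopropyl

This account rests on a few compounds, and the source may have more. Where it says the series, first, only, none or still open, it means among the compounds named here.

In an ADME assay on HepG2 cells (Homo sapiens) for cytotoxicity, read by MTT assay, with a stated time of 72 h (a higher number here means that more compound is tolerated, a lower number that less compound is tolerated), compound 1 (`CC(C)Nc1nc2ccsc2c(=O)[nH]1`) gives 23900 nM, while compound 2 (`Cc1ccc(-c2csc3c(=O)[nH]c(NC(C)(C)C)nc23)cc1`) gives 1400 nM. Compound 2 therefore has the lower of the two numbers, and the gap is beyond the usual scatter. Compound 3 (`Cc1ccc(-c2csc3c(=O)[nH]c(NC(C)C)nc23)cc1`) has not yet been measured. It differs from compound 2 in one place: hydrogen in place of methyl on a saturated chain carbon bound to a nitrogen on an aromatic ring and two saturated chain carbons. This is hydrogen in place of methyl on a saturated chain carbon bound to a nitrogen on an aromatic ring and two saturated chain carbons, so tert-butyl becomes isopropyl. Compound 1 also carries isopropyl, but it differs from compound 3 elsewhere too, which makes it a weak guide. In this assay, a small rise, close to the scatter, is expected, and the estimated change is a 1.4-fold higher number from compound 2 to compound 3 (0.15 log units; within the scatter). The estimate for compound 3 is 2000 nM, with an expected range of 800 nM to 5000 nM.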

Compound 3, half-maximal cytotoxic concentration: 8800 nM
Compound 3: the middle estimate sits 4.4-fold (0.64 log units) below what was measured, outside the stated range (above it).
By their numbers in this assay, from the lowest: compound 2; then compound 3; then compound 1.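

In this assay the loss of one methyl group matters: going from tert-butyl to isopropyl gives a 6.3-fold higher number from compound 2 to compound 3 (0.80 log units; beyond the scatter) and lies beyond the scatter, so this saturated chain carbon is a place where a small trim changes how much compound is tolerated. Isopropyl alone does not account for the whole picture, since adding 4-methylphenyl to the core gives a 2.7-fold lower number from compound 1 to compound 3 (0.43 log units; beyond the scatter) and also lies beyond the scatter, meaning that both places count among these compounds. Nothing measured here explains why either change has this effect.

On these data alone, whether trimming further continues the rise remains open, for example with ethyl or methyl in place of isopropyl. As far as these compounds go, it is also open whether a ring of similar size, such as cyclopropyl, behaves like isopropyl at this position.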